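The compounds below may be only part of what the source reports. "The series", "measured", "known", "first", "only" and "open" are said of these compounds alone.

Measured so far:
compound 1, `Cc1c(C(=O)Nc2c(F)cc(-c3cccc(F)c3)cc2F)nc2ccc(F)cc2c1O`, gives 75.2% in a functional assay on Hep 3B2 cells (Homo sapiens) for antiproliferative activity, read by MTT assay, with a stated time of 24 h, tested at 100 ug/mL; a higher number here means a stronger effect of the compound at the concentration tested, a lower number a weaker effect;
compound 2, `Cc1ccc2nc(C(=O)Nc3c(F)cc(-c4cccc(F)c4)cc3F)c(C)c(C(=O)O)c2c1`, gives 75.2%;
compound 3, `CCc1ccc2nc(C(=O)Nc3c(F)cc(-c4cccc(F)c4)cc3F)c(C)c(C(=O)O)c2c1`, gives 64.3%.

Compound 3 has the lowest of the three numbers. Its nearest neighbour is compound 1 and its furthest is compound 2, both the same distance away, and both gaps lie beyond the scatter. For the measured compounds named here, the one step that can be followed, a number 10.9 percentage points lower from compound 2 to compound 3 (beyond the scatter), is a modest loss when an ethyl replaces a methyl on the carbon-only ring of the shared core.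

Compound 4, `Cc1c(C(=O)Nc2c(F)cc(-c3cccc(F)c3)cc2F)nc2ccc(F)cc2c1C(=O)O`, differs from compound 3 in one place: fluoro in place of ethyl on an aromatic carbon. It thus removes the ethyl whose arrival cost compound 3 its number, and puts a fluoro there instead. Going by the values given here, no measured step swaps ethyl for fluoro directly. Compound 1 also carries a fluoro on that ring, but with a hydroxyl instead of the carboxylic acid, so its value can only hint. Since compound 2 sits where it does, 75.2%, the expected step of a number 7.7 percentage points higher from compound 3 to compound 4 (within the scatter) is a modest rise. Compound 4 is therefore estimated at 72%, between 60% and 82%.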

Compound 4, a percentage reported as inhibition, at one concentration (the size of the read-out at that concentration, not a potency): 65.2%
The estimate for compound 4 lay 6.8 percentage points above the measured number; low and high end bracket the measured number.
By their numbers in this assay, from the lowest: compounds 3, 4, 1 and 2 (each within the scatter of the next, the first and the last beyond it).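

Replacing the ethyl with fluoro on this aromatic carbon gives a number 0.9 percentage points higher from compound 3 to compound 4 (within the scatter) in this assay, so this change does not separate the two groups, and a fluoro at this place does not clearly undo what the ethyl cost. Against the methyl, the same position gives a number 10 percentage points lower from compound 2 to compound 4 (within the scatter), so fluoro cannot be separated from methyl either; of the three groups seen here, only ethyl and methyl lie beyond the scatter of each other, in a number 10.9 percentage points lower from compound 2 to compound 3 (beyond the scatter). At the other changed position, with fluoro on the ring in both compounds, a number 10 percentage points lower from compound 1 to compound 4 (within the scatter) shows that carboxy and hydroxy are not told apart in this assay, which is a read-out at one concentration and not a potency.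

No data given here bear on why any of these numbers fall where they do. Open, on these data alone, is how a chlorine, a methoxy group or a longer chain such as propyl would read on this aromatic carbon, and whether an amide or an ester in place of the carboxylic acid would stay level with compound 4.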